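This account rests on a few compounds, and the source may have more. Where it says the series, first, only, none or still open, it means among the compounds named here.

Measured compounds:
Compound 1, `COC1=C(N)C(=O)c2c(ccnc2-c2ccccn2)C1=O`, gives 12700 nM in a functional assay on the whole organism for inhibition, with Lepidium sativum as the target; on this read-out lower numbers stand for stronger inhibition and higher numbers for weaker inhibition.
Compound 2, `COC1=C(N)C(=O)c2c(ccnc2-c2cccc([N+](=O)[O-])c2)C1=O`, gives 6430 nM in this assay.
Compound 3, `COC1=C(N)C(=O)c2c(ccnc2-c2ccc(N)cc2)C1=O`, gives 15500 nM in this assay.

Of these three numbers, compound 3 stands highest, meaning the weakest inhibition seen so far. Its nearest neighbour is compound 1: the step of a 1.2-fold higher number from compound 1 to compound 3 (0.09 log units; within the scatter) lies within the scatter, so the two cannot be told apart. Compound 2 sits furthest away, and the two values show compound 2 with a clearly lower number.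

Compound 4, `COC1=C(N)C(=O)c2c(ccnc2-c2cccc(N)c2)C1=O`, has not yet been measured. It differs from compound 3 in one respect: 3-aminophenyl in place of 4-aminophenyl on an aromatic carbon. The same atoms are present; only the place of the amine on the phenyl ring changes. Within the data shown here, only one measured step concerns this attachment point, a 1.2-fold higher number from compound 1 to compound 3 (0.09 log units; within the scatter), and it was within the scatter even though a whole ring was exchanged. Among the measured compounds shown here, no measured step shows what moving the amine does. Compound 2 gives a lower number, but it differs from compound 3 in more than one way, so it offers no direct guide.

The expected step of a 1.4-fold lower number from compound 3 to compound 4 (0.15 log units; within the scatter) is therefore small and not beyond the scatter. Compound 4 is estimated at 11000 nM, in the range 4500 nM to 28000 nM.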

Compound 4, half-maximal inhibitory concentration: 22400 nM
Estimate against measurement, compound 4: 2.0-fold (0.31 log units) below, within the range that was stated.
By their numbers in this assay, from the lowest: compounds 2, 1, 3 and 4 (each within the scatter of the next, the first and the last beyond it).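

In this assay, 3-aminophenyl in place of 4-aminophenyl gives a 1.4-fold higher number from compound 3 to compound 4 (0.16 log units; within the scatter), so these two placings of the amine cannot be told apart. Swapping the whole ring also leaves no readable difference: 3-aminophenyl in place of pyridin-2-yl gives a 1.8-fold higher number from compound 1 to compound 4 (0.25 log units; within the scatter). Amino in place of nitro is the only one of these three changes that clears the scatter, with a 3.5-fold higher number from compound 2 to compound 4 (0.54 log units; beyond the scatter), a modest step towards weaker inhibition, so among these compounds the group carried by the phenyl ring changes the number, while moving the amine does not detectably do so.

No supporting data are available to explain why the amino and nitro compounds differ. From the compounds shown here alone, it remains open whether this step is particular to nitro, which a nitrile, a carboxylic acid or a methoxy group in place of the amino group of compound 4 could help to test, and whether a nitro group would give a different number if it took the place of the amino group in 4-aminophenyl.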